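Two-substituent change at the chain nitrogen of the shared core

A few compounds are considered here, and "the series" means these few. Any claim that something is new, unique, unknown or untested is made for them only; others in the source may bear on it.

Compound 1, `Nc1nc2ccc(C3CCCCC3)cc2s1`, is measured in a functional assay on the whole organism with Rattus norvegicus as the target (on this read-out higher numbers stand for an effect only at larger amounts of compound and lower numbers for an effect already at smaller amounts), only as a limit: compound 1 gives > 10 mg/kg, a limit of the assay and not a number. For the measured compounds named here, compound 2, `CCN(CC)C(=O)Cn1c(=N)sc2cc(OC(F)(F)F)ccc21`, carries the only number in this assay: compound 2 gives 9 mg/kg. Going by the values given here, it thus stands alone, the one further value being a limit, and the only bound to set it against is the limit of > 10 mg/kg in this assay, at which 1 of the 2 values shown sits.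

Compound 3, `CS(=O)(=O)CCCn1c(=N)sc2cc(OC(F)(F)F)ccc21`, is not yet measured in this assay. Against compound 2 the change is 2-(methylsulfonyl)ethyl in place of diethylcarbamoyl on a saturated chain carbon bound to an aromatic nitrogen. Among the compounds with values here, no step between two measured compounds with a related change exists, so nothing measured tells the direction or size of this exchange.

The expectation for compound 3 is therefore anchored on compound 2 alone, and the step from compound 2 to compound 3 is estimated as a 1.1-fold higher number from compound 2 to compound 3 (0.05 log units; within the scatter), i.e. within the usual scatter. In this assay compound 3 is expected to give 10 mg/kg, with a range from 3 mg/kg to 30 mg/kg, and a real chance that only a limit is reported.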

Compound 3, dose for half-maximal effect: 5 mg/kg
The estimate for compound 3 lay 2.0-fold (0.30 log units) above the measured number; low and high end bracket the measured number.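

For the compounds shown here, at the position on a saturated chain carbon bound to an aromatic nitrogen, the only readable step in this assay is a 1.8-fold lower number from compound 2 to compound 3 (0.26 log units; within the scatter), so this read-out does not tell 2-(methylsulfonyl)ethyl and diethylcarbamoyl apart. The two groups differ in make-up, with sulfur and a second oxygen in the entering chain, nitrogen in the leaving one, and more hydrogen-bond acceptors and double bonds outside aromatic rings in the entering group, yet the position takes either without a change that can be read beyond the scatter. Compound 1 remains a limit and not a number, and it differs from the other compounds in more than one place, so it adds no step: the limit of > 10 mg/kg in this assay, at which 1 of the 3 values shown sits.

Still open, as far as these compounds go, is whether this position stays as permissive for a group of another kind, such as a terminal dimethylamine, a carboxylic acid or a longer chain ending in methylsulfonyl. One step within the scatter also leaves open whether the same exchange would read alike on a core without the trifluoromethoxy group.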